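The source may report more compounds than this note shows. Statements on the series, on what has been measured and on what is new or still open speak of the compounds shown alone.

Of the compounds shown here, two have so far been measured in a functional assay on the whole organism (plasma) with Mus musculus as the target, with a stated time of 180 min, at a dose of 200 umol/kg by the oral route; a higher number here means more inhibition at the dose given (going by the name of the read-out), a lower number less inhibition. Compound 1 `CCC[C@H](C(N)=O)N(Cc1ccc(OC)c(F)c1)S(=O)(=O)c1ccc(Cl)cc1` gives 41%, while compound 2 `N#Cc1ccc(CN([C@H](CC2CC2)C(N)=O)S(=O)(=O)c2ccc(Cl)cc2)cc1` gives 81%, the higher of the two numbers, with a gap to compound 1 that lies beyond the scatter. Compound 3 `NC(=O)[C@@H](CC1CC1)N(Cc1ccc(C(F)(F)F)cc1)S(=O)(=O)c1ccc(Cl)cc1` has not yet been measured in this assay; it differs from compound 2 by trifluoromethyl in place of cyano on an aromatic carbon. Within the data shown here, no measured pair shows this change, so its size is unknown; a modest decrease is expected, a number 13 percentage points lower from compound 2 to compound 3 (beyond the scatter), though a step within the scatter would not surprise. Compound 3 is therefore estimated at 68%, in a range from 42% to 90%.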

Compound 3, a percentage reported as inhibition, in the whole organism at one dose (the size of the read-out at that dose, not a potency): 65%
Compound 3: the middle estimate sits 3 percentage points above what was measured, within the range that was stated.
By their numbers in this assay, from the lowest: compound 1; then compound 3; then compound 2.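

In this assay, the change from 4-cyanophenyl to 4-(trifluoromethyl)phenyl gives a number 16 percentage points lower from compound 2 to compound 3 (beyond the scatter). The group on this aromatic carbon, para to a large group, therefore affects the read-out at this dose while the rest of the structure stays the same. Nothing measured here accounts for the step.

On these data alone, it remains open how an amine or a carboxylic acid on this same carbon would compare with the nitrile and the trifluoromethyl group. As far as these compounds go, it is also open whether this step would recur on a different core.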